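The compounds below may be only part of what the source reports. "The series", "measured", "known", "first", "only" and "open" are said of these compounds alone.

Measured so far in an assay on isolated protein for inhibition of thyroid hormone receptor beta (Homo sapiens), read by fluorescence, with a stated time of 30 min; a higher number here means a weaker inhibitor, a lower number a stronger inhibitor: compound 1 `COc1cc(C(=O)N2CCC(C)(C)C2)cc2nc(NCc3cccc(Cl)c3)oc12` gives 40 nM; compound 2 `COc1cc(C(=O)N2CC[C@@H](O)C(C)(C)C2)cc2nc(NCc3cccc(Cl)c3)oc12` gives 35 nM; compound 3 `COc1cc(C(=O)N2CCC(O)C(C)C2)cc2nc(NCc3cccc(Cl)c3)oc12` gives 25 nM.

Compound 3 has the lowest number of the three, but the steps leading to it, a 1.6-fold lower number from compound 1 to compound 3 (0.20 log units; within the scatter) and a 1.4-fold lower number from compound 2 to compound 3 (0.15 log units; within the scatter), are both within the scatter, as is a 1.1-fold lower number from compound 1 to compound 2 (0.06 log units; within the scatter), so the three compounds cannot be told apart on these numbers. Compound 4 `COc1cc(C(=O)N2CCC(O)C(C)C2)cc2nc(N[C@H](C)c3cccc(Cl)c3)oc12` differs from compound 3 by methyl in place of hydrogen on a saturated chain carbon bound to an aromatic carbon and a nitrogen on an aromatic ring. Among the compounds with values here, all three measured steps change only the amide side of the shared core; none of them touches this chain carbon, so no measured step bears on the change. Without such a precedent, the expectation is a step no larger than the scatter, a 1.1-fold higher number from compound 3 to compound 4 (0.05 log units; within the scatter), in no particular direction. Compound 4 is therefore estimated at 28 nM in this assay, with a range from 8 nM to 100 nM.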

Compound 4, half-maximal inhibitory concentration: 48 nM
Beside the measured number, compound 4's estimate is 1.7-fold (0.23 log units) below it, within the range that was stated.
By their numbers in this assay, from the lowest: compounds 3, 2, 1 and 4 (each within the scatter of the next).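

Within the data shown here, at the saturated chain carbon bound to an aromatic carbon and a nitrogen on an aromatic ring, methyl in place of hydrogen gives a 1.9-fold higher number from compound 3 to compound 4 (0.28 log units; within the scatter) and is the first measured change at this position. This single added carbon therefore leaves the number within the scatter, so the position tolerates methyl at least in this one compound pair. No measurement available here accounts for the size of this step. Ethyl, a longer chain or an amine on this same carbon remains open. So does the opposite mirror-image arrangement of the methyl.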